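Series notes: substituent exchanges on one aromatic carbon

This account rests on a few compounds, and the source may have more. Where it says the series, first, only, none or still open, it means among the compounds named here.

Compound 1 `CCCc1cc(OC)cc(=O)n1Cc1ccc(-c2ccccc2-c2nn[nH]n2)cc1`, compound 2 `CCCc1cc(SC)cc(=O)n1Cc1ccc(-c2ccccc2-c2nn[nH]n2)cc1` and compound 3 `CCCc1cc(CO)cc(=O)n1Cc1ccc(-c2ccccc2-c2nn[nH]n2)cc1` share one core and differ only in the group carried on a single aromatic carbon. In a functional assay on the whole organism with Rattus norvegicus as the target (on this read-out higher numbers stand for an effect only at larger amounts of compound and lower numbers for an effect already at smaller amounts), compound 1 gives 0.24 mg/kg, compound 2 gives 0.28 mg/kg and compound 3 gives 0.3 mg/kg. The three exchanges among them are all small: a 1.2-fold higher number from compound 1 to compound 2 (0.07 log units; within the scatter), a 1.3-fold higher number from compound 1 to compound 3 (0.10 log units; within the scatter) and a 1.1-fold higher number from compound 2 to compound 3 (0.03 log units; within the scatter). Compound 3 holds the highest of the three numbers, yet both other compounds lie within the scatter of it, so no order among the three can be read from this assay.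

Compound 4 `CCCc1cc(OCc2cccnc2)cc(=O)n1Cc1ccc(-c2ccccc2-c2nn[nH]n2)cc1` has not been measured. The change from compound 3 is (pyridin-3-yl)methoxy in place of hydroxymethyl on an aromatic carbon. All three measured steps bear on it, as each also exchanged the group on this same aromatic carbon, and none moved the number beyond the scatter. Each of those steps, however, swapped groups of comparable small size, whereas here a considerably larger group enters, so the measured steps cover the place of the change but not its extent. The expectation is therefore no step beyond the scatter, with a widened range to reflect the untested size of the group. For compound 4 in this assay the expected value is 0.3 mg/kg, within 0.12 mg/kg to 0.9 mg/kg. The expected step is no change at the digits printed from compound 3 to compound 4 (within the scatter).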

Compound 4, dose for 50% inhibition: 0.72 mg/kg
Beside the measured number, compound 4's estimate is 2.4-fold (0.38 log units) below it; the measured number falls inside the stated range.
By their numbers in this assay, from the lowest: compounds 1, 2 and 3 (each within the scatter of the next); then compound 4.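

In this assay this aromatic carbon, opposite the ring nitrogen, no longer appears indifferent to the group it carries, since the entry of (pyridin-3-yl)methoxy gives a 2.4-fold higher number from compound 3 to compound 4 (0.38 log units; beyond the scatter) as well as a 2.6-fold higher number from compound 2 to compound 4 (0.41 log units; beyond the scatter) and a 3.0-fold higher number from compound 1 to compound 4 (0.48 log units; beyond the scatter) in the same direction. Read against the methoxy group, the exchange is the single replacement of a hydrogen on the saturated chain carbon bound to the oxygen by pyridin-3-yl, and this addition is what separates compound 4 from the small groups, though each step remains modest and the position still accepts a group with a six-membered aromatic ring. The data offer no measured basis for explaining this shift.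

Compound 4 alone cannot show whether the shift follows from the added size, the aromatic ring or the ring nitrogen, and a benzyloxy group or a longer chain such as butoxy on the same carbon would help to separate these. Also open, on these data alone, is how a pyridin-2-yl or pyridin-4-yl isomer, or an amine such as aminomethyl, would read out at this position.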